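Swapping One Group on a Compound at the Assay Limit

The compounds below may be only part of what the source reports. "The series", "measured", "known", "first", "only" and "open" are said of these compounds alone.

Measured in a toxicity assay on HeLa cells (Homo sapiens) for cytotoxicity, read by colorimetric assay, with a stated time of 72 h; on this read-out higher numbers stand for lower toxicity in this test and lower numbers for higher toxicity in this test:
- compound 1 `O=c1nc(N2CC[C@@](O)(COc3ccc(F)cc3)[C@H](O)C2)sc2c([N+](=O)[O-])cc(C(F)(F)F)cc12`: 18400 nM
- compound 2 `N#Cc1ccccc1N1CCN(c2nc(=O)c3cc(C(F)(F)F)cc([N+](=O)[O-])c3s2)CC1`: > 108000 nM (a limit, not a number)

Compound 2 gives > 108000 nM, which is only a limit of the assay and not a number. Compound 3 `O=c1nc(N2CCN(Cc3ccncc3)CC2)sc2c([N+](=O)[O-])cc(C(F)(F)F)cc12` keeps the shared core but carries (pyridin-4-yl)methyl in place of 2-cyanophenyl on an amine nitrogen in a ring. Among the compounds with values here, no measured pair shows what this swap does, so the expectation is loose. Within the data shown here, with compound 1 at 18400 nM as the only true number, a moderate move toward lower numbers in this assay is expected, meaning higher toxicity. A reading at the limit remains possible for compound 3. The expected change is an at least 2.1-fold lower number from compound 2 to compound 3 (0.33 log units; beyond the scatter). For compound 3 the estimated value is 50000 nM, with an expected range from 15000 nM to 150000 nM.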

Compound 3, half-maximal cytotoxic concentration: > 111000 nM
Compound 3: no number, only a limit (the forecaster's own chance of this, stated with the estimate: 30%); middle value at least 2.2-fold (0.34 log units) away from the limit.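

In this assay compound 2 gives > 108000 nM, which is a limit and not a number. Within the data shown here, compound 3 gives > 111000 nM, also a limit, so no step between compound 2 and compound 3 can be read. Going by these compounds, whether (pyridin-4-yl)methyl in place of 2-cyanophenyl changes the true value at all, and by how much, stays open.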